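The source may report more compounds than this note shows. Statements on the series, on what has been measured and on what is new or still open speak of the compounds shown alone.

Measured compounds:

compound 1 `CC(=O)Nc1ccc(S(=O)(=O)Nc2cccc(-c3nc(-c4ccc(NC(=O)c5cccnc5)c(C(F)(F)F)c4)no3)c2)cc1` — > 10000 nM
compound 2 `CC(=O)Nc1ccc(S(=O)(=O)Nc2cccc(-c3nc(-c4ccc(NC(=O)c5cccnc5)cc4C(F)(F)F)no3)c2)cc1` — > 10000 nM
compound 3 `COc1cc(-c2noc(-c3cccc(NS(=O)(=O)c4ccc(NC(C)=O)cc4)c3)n2)ccc1NC(=O)c1cccnc1` — > 10000 nM

In a functional assay on MDA-MB-231 cells (Homo sapiens) for antiproliferative activity, read by MTT assay, with a stated time of 72 h (on this read-out higher numbers stand for weaker inhibition and lower numbers for stronger inhibition), compound 1 gives > 10000 nM, which is a limit of the assay and not a number. Compound 2 gives > 10000 nM in this assay, likewise a limit. Compound 3 also sits at a limit, > 10000 nM in this assay. All three therefore share (the limit of > 10000 nM in this assay, at which 3 of the 3 values shown sit).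

Compound 1 and compound 2 are built from the same atoms joined differently; the difference between their cores is not broken down here. Compound 3 arises from compound 1 by methoxy in place of trifluoromethyl on an aromatic carbon. The step that the two limits leave unreadable from compound 1 to compound 3 cannot be read, as both ends are limits.

Compound 4 `COc1cc(NC(=O)c2cccnc2)ccc1-c1noc(-c2cccc(NS(=O)(=O)c3ccc(NC(C)=O)cc3)c2)n1` is unmeasured and arises from compound 2 by methoxy in place of trifluoromethyl on an aromatic carbon. This is the same kind of change as from compound 1 to compound 3, but not the same: in compound 3 the methoxy is ortho to the ((pyridin-3-yl)carbonyl)amino group and meta to a large group, whereas in compound 4 it is ortho to a large group and meta to the ((pyridin-3-yl)carbonyl)amino group.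

Given that compound 2 sits at the limit > 10000 nM, and that the comparable change left compound 3 at a limit too, compound 4 is expected to stay at or near the limit, an expected step that the limit leaves unreadable from compound 2 to compound 4. The estimate for compound 4 in this assay is 20000 nM, expected between 8000 nM and 60000 nM, most likely reported only as a limit.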

Compound 4, half-maximal inhibitory concentration: > 10000 nM
Compound 4: no number, only a limit (the forecaster's own chance of this, stated with the estimate: 85%); the middle value lies beyond the limit too.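

In this assay no step can be read between compound 2 and compound 4, as each gives a limit and not a number: the limit of > 10000 nM in this assay, at which 4 of the 4 values shown sit.

The compounds shown leave open how far compound 1, compound 2, compound 3 and compound 4 each lie beyond that limit, and whether methoxy in place of trifluoromethyl changes antiproliferative activity at either place.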